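This account rests on a few compounds, and the source may have more. Where it says the series, first, only, none or still open, it means among the compounds named here.

The measured compounds, each with its result:

Compound 1, `N#Cc1c(N)nc(SCc2cccc(C(N)=O)c2)c(C#N)c1-c1ccc(OCC2CC2)cc1`, gives 1% in an assay on CHO cells for displacement of a labelled ligand from adenosine receptor A3 (Homo sapiens), read by scintillation counting, with a stated time of 120 min, tested at 1 uM; on this read-out higher numbers stand for more inhibition at the one concentration tested (going by the name of the read-out) and lower numbers for less inhibition.
Compound 2, `N#Cc1c(N)nc(SCc2nnn[nH]2)c(C#N)c1-c1ccc(OCC2CC2)cc1`, gives 1%.
Compound 3, `CC(C)COc1ccc(-c2c(C#N)c(N)nc(SCC(N)=O)c2C#N)cc1`, gives 9%.

All three compounds share one core and differ only in the group carried on the saturated chain carbon bound to the sulfur. Compound 2 stands level with compound 1, and the gap from compound 2 to compound 3 also lies within the scatter, so none of the three can be set above the others.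

The next compound, compound 4, `N#Cc1c(N)nc(SCc2cccnc2)c(C#N)c1-c1ccc(OCC2CC2)cc1`, changes the same place once more: pyridin-3-yl in place of 1H-tetrazol-5-yl on a saturated chain carbon bound to a sulfur.

Among the compounds with values here, only one measured step touches that place. Replacing 3-carbamoylphenyl by 1H-tetrazol-5-yl there gave no change at the digits printed from compound 1 to compound 2 (within the scatter). Nothing measured involves pyridin-3-yl, so the expectation rests on that single step and on the flat level of all three numbers. The step from compound 2 to compound 4 is therefore expected to be small, a number 4 percentage points higher from compound 2 to compound 4 (within the scatter), with no direction that stands out beyond the scatter.

Compound 4 is thus estimated at 5%, within a range from 0% to 20%.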

Compound 4, a percentage reported as inhibition, at one concentration (the size of the read-out at that concentration, not a potency): 19%
The estimate for compound 4 lay 14 percentage points below the measured number; the range from low to high includes it.
By their numbers in this assay, from the lowest: compounds 1, 2, 3 and 4 (each within the scatter of the next, the first and the last beyond it).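

At this place, on a saturated chain carbon bound to a sulfur, the group can shift the result in this assay: pyridin-3-yl in place of 1H-tetrazol-5-yl gives a number 18 percentage points higher from compound 2 to compound 4 (beyond the scatter), and pyridin-3-yl in place of 3-carbamoylphenyl gives a number 18 percentage points higher from compound 1 to compound 4 (beyond the scatter). Within the data shown here, these are the first steps at this place that lie beyond the scatter, so the flat level of the earlier numbers does not hold for every group, although compound 4 still reaches only 19% at the one concentration tested, which is not a measure of potency. The step from the tetrazole changes ring size, the number of hetero atoms, and the donor and acceptor counts all at once, and nothing shown explains the higher number or singles out one of these differences.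

A plain phenyl group at the same place would show whether the ring nitrogen of pyridin-3-yl matters at all, or whether an aromatic ring without the amide or the tetrazole is enough. A longer chain between the sulfur and the pyridine ring, or an amine in place of that ring, would show how far the higher number depends on this exact group.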